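A Methoxy Swap on a Weakly Active Pair

The compounds below may be only part of what the source reports. "The series", "measured", "known", "first", "only" and "open" are said of these compounds alone.

In a functional assay on CAPAN-1 cells (Homo sapiens) for antiproliferative activity, with a stated time of 72 h (a higher number here means a weaker inhibitor, a lower number a stronger inhibitor), compound 1 `Nc1ncnn2c([C@@H]3O[C@H](CO)[C@@H](O)[C@H]3O)cc(-c3ccc(F)cc3)c12` gives 65600 nM and compound 2 `Nc1ncnn2c([C@@H]3O[C@H](CO)[C@@H](O)[C@H]3O)cc(-c3ccc(F)cc3F)c12` gives 50900 nM so compound 2 stands level with compound 1 within the usual scatter. Compound 3 `COc1ccc(-c2cc([C@@H]3O[C@H](CO)[C@@H](O)[C@H]3O)n3ncnc(N)c23)cc1` differs from compound 2 in one place, with 4-methoxyphenyl in place of 2,4-difluorophenyl on an aromatic carbon and the rest of the structure unchanged. Within the data shown here, only one measured step bears on this change: a 1.3-fold lower number from compound 1 to compound 2 (0.11 log units; within the scatter) for fluoro in place of hydrogen on the same phenyl group. Among the measured compounds shown here, that is a single small step, and no measured compound carries a methoxy group, so the data point in no clear direction. No shift beyond the scatter is therefore expected in this assay and the expected step is a 1.1-fold lower number from compound 2 to compound 3 (0.05 log units; within the scatter) in size. For compound 3 the estimated value is 45000 nM with an expected range of 15000 nM to 120000 nM around it.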

Compound 3, half-maximal inhibitory concentration: 43900 nM
Beside the measured number, compound 3's estimate is 1.0-fold (0.01 log units) above it, within the range that was stated.
By their numbers in this assay, from the lowest: compounds 3, 2 and 1 (each within the scatter of the next).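

In this assay, the change from 2,4-difluorophenyl to 4-methoxyphenyl gives a 1.2-fold lower number from compound 2 to compound 3 (0.06 log units; within the scatter), and the change from fluoro to methoxy gives a 1.5-fold lower number from compound 1 to compound 3 (0.17 log units; within the scatter). Until now, this position had been tested only with fluoro in place of hydrogen; these steps show that a swap to a different kind of group, one with an oxygen and a hydrogen-bond acceptor where the earlier groups have none, also leaves the number within the scatter. Nothing available here explains why the three compounds stay level.

From the compounds shown here alone, all three compounds carry a substituted phenyl group at this carbon, so the reach of this position remains unknown. An amine or a carboxylic acid on that phenyl group, or a longer chain in its place, could still show whether this position can move the number beyond the scatter.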